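Methoxy for Fluoro at the Limit of Measurement

The compounds below may be only part of what the source reports. "The series", "measured", "known", "first", "only" and "open" are said of these compounds alone.

In an ADME assay on WI-38 cells (Homo sapiens) for cytotoxicity, read by MTT assay, with a stated time of 48 h (a higher number here means a weaker inhibitor, a lower number a stronger inhibitor), compound 1 (`CC(C)(Oc1ccc(Cl)cc1)C(=O)NCCOC(=S)Nc1ccc(F)cc1`) gives > 800000 nM, which is a limit and not a number. Compound 2 (`COc1ccc(NC(=S)OCCNC(=O)C(C)(C)Oc2ccc(Cl)cc2)cc1`) gives a true number, 780000 nM. Compound 3 (`O=C(NCCOC(=S)Nc1ccc(F)cc1)c1cccnc1`) gives > 800000 nM, which is also a limit. Its position is therefore known only as a limit, and the one other limit shown is the same.

Compound 4 (`COc1ccc(NC(=S)OCCNC(=O)c2cccnc2)cc1`) differs from compound 3 by methoxy in place of fluoro on an aromatic carbon. In words, this is methoxy in place of fluoro on an aromatic carbon, para to a large group. The same exchange has been measured once in this set, and that step bears directly on the new one: an at least 1.0-fold lower number from compound 1 to compound 2 (0.01 log units; that floor lies within the scatter). Its size is known only as a floor due to the limit of > 800000 nM in this assay, at which 2 of the 3 values shown sit. Going by these compounds, this single step gives no sign of a change beyond the scatter, so none is expected here, and the direction remains open. Compound 4 may also return only a limit.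

The expected result is an at least 1.0-fold lower number from compound 3 to compound 4 (0.02 log units; that floor lies within the scatter), a step not expected to exceed the scatter. The estimated half-maximal inhibitory concentration for compound 4 is 750000 nM, with an expected range from 450000 nM to 900000 nM.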

Compound 4, half-maximal inhibitory concentration: 781000 nM
Compound 4: the middle estimate sits 1.0-fold (0.02 log units) below what was measured, and the stated range covers the measured number.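

Methoxy in place of fluoro, on an aromatic carbon para to a large group, now has a second reading on a different core. In this assay, the step is an at least 1.0-fold lower number from compound 3 to compound 4 (0.01 log units; that floor lies within the scatter), so compound 4 adds a case in which this exchange shows no change beyond the scatter, although the step is known only as a floor. Taken together, the two cores can be described only in these terms: the same change on two cores in this assay, an at least 1.0-fold lower number (0.01 log units; that floor lies within the scatter) from compound 1 to compound 2 and an at least 1.0-fold lower number (0.01 log units; that floor lies within the scatter) from compound 3 to compound 4; the limit leaves it open whether they differ

The true size of each step remains unknown, and the fluoro side of both pairs gives no number, because of the ceiling of the assay: the limit of > 800000 nM in this assay, at which 2 of the 4 values shown sit. The compounds shown also leave open whether an amine or a carboxylic acid on this same aromatic carbon, or a longer chain ending in an oxygen there, would give a number clearly lower than those of the methoxy compounds, which would show whether this position can affect the read-out at all.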